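A few compounds are considered here, and "the series" means these few. Any claim that something is new, unique, unknown or untested is made for them only; others in the source may bear on it.

Compound 3 `C=C1C(=O)OC[C@H]1CCOC(=O)Nc1cc(C)cc(C)c1` gives 480 nM in a functional assay on RAW264.7 cells (Mus musculus) for inhibition, with a stated time of 30 min (on this read-out lower numbers stand for stronger inhibition and higher numbers for weaker inhibition), the lowest of the three numbers shown, although compound 2 `C=C1C(=O)OC[C@H]1CCOC(=O)Nc1ccc(CCCC)cc1` with 620 nM and compound 1 `C=C1C(=O)OC[C@H]1CCOC(=O)Nc1ccc(OC)cc1` with 710 nM both lie within the scatter of it. Among the compounds with values here, the only single-change step among the measured compounds, a 1.1-fold lower number from compound 1 to compound 2 (0.06 log units; within the scatter), exchanges one ring substituent for another and says nothing about configuration. Compound 4 `C=C1C(=O)OC[C@@H]1CCOC(=O)Nc1cc(C)cc(C)c1` differs from compound 3 by the two compounds have the same atoms and bonds and differ only in configuration as drawn: 1 of 1 stereo elements differ; a stereocentre at a saturated ring carbon is drawn S in compound 3 and R in compound 4. Within the data shown here, no measured step bears on a change of this kind, so neither the size nor the direction of the step in this assay can be read from these data, and the range must stay wide. For compound 4 the estimated value is 900 nM, between 300 nM and 3000 nM, which means an expected step of a 1.9-fold higher number from compound 3 to compound 4 (0.27 log units; within the scatter).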

Compound 4, half-maximal inhibitory concentration: 1240 nM
Compound 4: middle estimate off by 1.4-fold (0.14 log units), on the low side; the range from low to high includes it.
By their numbers in this assay, from the lowest: compounds 3, 2, 1 and 4 (each within the scatter of the next, the first and the last beyond it).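

In this assay, within the data shown here, inverting the stereocentre at a saturated ring carbon from S to R gives a 2.6-fold higher number from compound 3 to compound 4 (0.41 log units; beyond the scatter), so this position responds to configuration, whereas the one earlier single-change step, between ring substituents, stayed within the scatter. The step can be assigned to that stereocentre alone, for one reason: the fact that compounds 3 and 4 differ only in the configuration as drawn

The compounds shown leave open whether the same step would appear with methoxy or butyl on the aromatic ring. They also leave open how a carboxylic acid or an amine at that ring would read out.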